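This account rests on a few compounds, and the source may have more. Where it says the series, first, only, none or still open, it means among the compounds named here.

Measured compounds in a functional assay on NCI-H460 cells (Homo sapiens) for cytotoxicity, read by MTT assay, with a stated time of 72 h; on this read-out higher numbers stand for weaker inhibition and lower numbers for stronger inhibition:
compound 1 `COc1cc2c(Oc3ccc(NC(=O)c4nnn(-c5ccccc5C)c4C)cc3F)ccnc2cc1OCCCN1CCCC1`, 720 nM
compound 2 `COc1cc2c(Oc3ccc(NC(=O)c4nnn(-c5ccccc5)c4C)cc3F)ccnc2cc1OCCCN1CCCC1`, 160 nM
compound 3 `COc1cc2c(Oc3ccc(NC(=O)c4nnn(-c5ccccc5C)c4C)cc3F)ccnc2cc1OCCCN1CCCCC1`, 780 nM

Compound 3 gives the highest number of the three. Its nearest neighbour is compound 1, and the step between them is within the scatter: a 1.1-fold higher number from compound 1 to compound 3 (0.03 log units; within the scatter). Compound 2 stands furthest away at 160 nM, a gap from compound 3 that lies beyond the scatter.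

Compound 4 `COc1cc2c(Oc3ccc(NC(=O)c4nnn(-c5ccccc5)c4C)cc3F)ccnc2cc1OCCCN1CCCCC1` differs from compound 3 in one place: hydrogen in place of methyl on an aromatic carbon. The same change has been measured once already in this series, between compound 1 and compound 2, where it gave a 4.5-fold lower number from compound 1 to compound 2 (0.65 log units; beyond the scatter), a modest step beyond the scatter toward a lower number. Compound 1 and compound 3 differ only in the pyrrolidin-1-yl versus piperidin-1-yl group on the chain, and a 1.1-fold higher number from compound 1 to compound 3 (0.03 log units; within the scatter) shows that this exchange left the number essentially unchanged, so the response to removing the methyl is expected to carry over to the piperidin-1-yl pair. For compound 4 a step of a 4.5-fold lower number from compound 3 to compound 4 (0.65 log units; beyond the scatter) toward a lower number is therefore expected. The estimate for compound 4 in this assay is 175 nM, with a range from 80 nM to 400 nM.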

Compound 4, half-maximal inhibitory concentration: 220 nM
Estimate against measurement, compound 4: 1.3-fold (0.10 log units) below; low and high end bracket the measured number.
By their numbers in this assay, from the lowest: compounds 2 and 4 (each within the scatter of the next); then compounds 1 and 3 (each within the scatter of the next).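

Notes on the 2-methylphenyl to phenyl change in this assay: with the piperidin-1-yl chain in place, a 3.5-fold lower number from compound 3 to compound 4 (0.55 log units; beyond the scatter), so the lower number on loss of the methyl ortho to a large group is no longer a single reading from the pyrrolidin-1-yl pair, and the two steps agree: the same change on two cores in this assay, a 4.5-fold lower number (0.65 log units; beyond the scatter) from compound 1 to compound 2 and a 3.5-fold lower number (0.55 log units; beyond the scatter) from compound 3 to compound 4, 1.3-fold (0.10 log units) apart, within the scatter of two such steps.

The chain exchange, so far read only with the 2-methylphenyl group, now also reads with the phenyl group as a 1.4-fold higher number from compound 2 to compound 4 (0.14 log units; within the scatter), and again the two readings agree: the same change on two cores in this assay, a 1.1-fold higher number (0.03 log units; within the scatter) from compound 1 to compound 3 and a 1.4-fold higher number (0.14 log units; within the scatter) from compound 2 to compound 4, 1.3-fold (0.10 log units) apart, within the scatter of two such steps.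

Across these four compounds the number therefore follows the methyl and not the choice of pyrrolidin-1-yl or piperidin-1-yl, and no compound shown goes against this.

Still open, on these data alone, is whether a chloro or methoxy group at the same place, ortho to a large group, keeps the number near that of compound 3 or near that of compound 4, since only methyl and hydrogen are compared there. Also open, as far as these compounds go, is whether the indifference to the chain extends to a morpholin-4-yl group or a dimethylamino group at its end, or to a longer chain.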